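The source may hold more compounds than are shown below. What is called first, only, known or untested is meant among the compounds shown, and "the series" means these compounds.

Of the compounds shown here, three sharing one core have been tested in a functional assay on HeLa cells (Homo sapiens) for cytotoxicity, read by XTT assay, with a stated time of 48 h; on this read-out lower numbers stand for stronger inhibition and higher numbers for weaker inhibition. Compound 1 `N=C(N)NCCC[C@H](NC(=O)[C@H](CCCCN)NC(=O)N1C/C(=C\c2ccc(Cl)c(Cl)c2)C(=O)/C(=C/c2ccc(Cl)c(Cl)c2)C1)C(=O)O` gives > 50000 nM, which is a limit of the assay and not a number. Compound 2 `O=C(O)CC[C@H](NC(=O)N1C/C(=C\c2ccc(Cl)c(Cl)c2)C(=O)/C(=C/c2ccc(Cl)c(Cl)c2)C1)C(=O)N[C@@H](CC(=O)O)C(=O)O` gives > 50000 nM, again a limit. Compound 3 `O=C(O)CC[C@H](NC(=O)N1C/C(=C\c2ccc(Cl)c(Cl)c2)C(=O)/C(=C/c2ccc(Cl)c(Cl)c2)C1)C(=O)O` gives > 50000 nM, also a limit, so its position is known only as a bound. All the readings so far come down to the limit of > 50000 nM in this assay, at which 3 of the 3 values shown sit.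

Compound 4 `NCCCC[C@H](NC(=O)N1C/C(=C\c2ccc(Cl)c(Cl)c2)C(=O)/C(=C/c2ccc(Cl)c(Cl)c2)C1)C(=O)O` has not yet been measured in this assay. It differs from compound 3 by 2-aminoethyl in place of carboxy on a saturated chain carbon, three bonds along the chain from an amide-type nitrogen and a carbonyl carbon, with 2-aminoethyl in place of carboxy on a saturated chain carbon, three bonds along the chain from an amide-type nitrogen and a carbonyl carbon. Cut one bond further out, the same change reads 2-carboxyethyl to 4-aminobutyl.

Among the compounds with values here, the only measured step reaching compound 3 is a step that the two limits leave unreadable from compound 2 to compound 3, so it offers no size to carry over. Within the data shown here, no measured step shows this particular change, and the data give no direction for it. The expectation therefore stays close to the starting point, with no shift beyond the scatter and quite possibly another limit. The expected step, an estimate only, is an at least 1.1-fold lower number from compound 3 to compound 4 (0.04 log units; that floor lies within the scatter). The estimated value for compound 4 is 45000 nM, within an expected range of 15000 nM to 80000 nM.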

Compound 4, half-maximal inhibitory concentration: > 50000 nM
Compound 4 ended at the assay's limit (the forecaster's own chance of this, stated with the estimate: 70%); middle value at least 1.1-fold (0.04 log units) from the limit.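

In this assay, compound 4 gives > 50000 nM, which is a limit of the assay and not a number. The steps to it from compound 3 and from compound 1 therefore cannot be read. Left open is whether 2-aminoethyl in place of carboxy, or any other difference among these compounds, shifts the reading at all, with every compound resting on one bound: the limit of > 50000 nM in this assay, at which 4 of the 4 values shown sit.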